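The source may hold more compounds than are shown below. What is called first, only, known or untested is meant among the compounds shown, and "the series" means these compounds.

Measured in a functional assay on HeLa cells (Homo sapiens) for antiproliferative activity, read by sulforhodamine B assay, with a stated time of 72 h; a lower number here means a stronger inhibitor, a higher number a weaker inhibitor:
- compound 1 `S=C(NNc1nncc2ccccc12)Nc1ccccc1`: 39 nM
- compound 2 `O=S(=O)(Nc1ncccn1)c1ccc(Nc2nncc3ccccc23)cc1`: 14 nM
- compound 3 `Fc1ccc(Nc2nncc3ccccc23)cc1`: 2.8 nM

Compound 3 (2.8 nM) has the lowest number of the three, and its gaps to compound 2 and to compound 1 both lie beyond the scatter. The next compound, compound 4 `N#Cc1ccc(Nc2nncc3ccccc23)cc1`, keeps the shared core and has cyano in place of fluoro on an aromatic carbon, para to a large group (cyano in place of fluoro on an aromatic carbon). For the measured compounds named here, no pair of measured compounds differs in one place only, so no measured step speaks directly to this change.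

The expectation therefore rests on three values. Compound 3 gives 2.8 nM. Compound 2 (14 nM) also has a group in that place and stands higher, although the two groups differ greatly in size. Starting from the low end of the series, a modest rise in the number is expected in this assay, and a result within the scatter would be no surprise. The expected change is a 2.1-fold higher number from compound 3 to compound 4 (0.33 log units; beyond the scatter). The estimated value for compound 4 is 6 nM, with an expected range of 1.5 nM to 30 nM.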

Compound 4, half-maximal inhibitory concentration: 1.5 nM
Compound 4: middle estimate off by 4.0-fold (0.60 log units), on the high side, and the stated range covers the measured number.
By their numbers in this assay, from the lowest: compounds 4 and 3 (each within the scatter of the next); then compound 2; then compound 1.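

For the compounds shown here, this is the first step that changes one place only: the substituent on an aromatic carbon of the six-membered aromatic ring of carbon only, para to a large group. In this assay cyano in place of fluoro gives a 1.9-fold lower number from compound 3 to compound 4 (0.27 log units; within the scatter) and so separates the two compounds by no more than repeated measurements would, even though the entering group brings 1 triple bond and 1 hydrogen-bond acceptor and the leaving group has neither. Nothing shown here explains this outcome or links it to a measured property of either group.

As far as these compounds go, only these two small groups have been compared directly at this place, so it remains open whether an amine, a carboxylic acid, a methoxy group or a longer chain would keep the number in the same range. Compound 1 and compound 2 each differ from compound 4 in more than one place, so they do not show how a larger group at this place acts on its own.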